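A few compounds are considered here, and "the series" means these few. Any claim that something is new, unique, unknown or untested is made for them only; others in the source may bear on it.

Compounds measured so far:
compound 1, `CCOc1ccc(C(=O)Nc2cc(C)cc(C)n2)cc1`, 17100 nM
compound 2, `C=CCOc1ccc(C(=O)Nc2ccccn2)cc1`, 19300 nM
compound 3, `CCCOc1ccc(C(=O)Nc2cccc(N3CCCCC3)n2)cc1`, only a limit, > 100000 nM

These three share an amide-linked core and were tested in an in vitro assay on HEK-tsA201 cells for antagonist activity at Neuronal acetylcholine receptor; alpha4/beta2 (Homo sapiens), read by fluorescence and calcium flux; on this read-out higher numbers stand for weaker inhibition and lower numbers for stronger inhibition. Compound 2 gives the higher of the two real numbers, with compound 1 its nearest neighbour; the gap between them lies within the scatter of this assay, so no order can be read from it. Compound 3 stands apart: its result is a limit, not a number, since it reached (the limit of > 100000 nM in this assay, at which 1 of the 3 values shown sits).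

Compound 4, `C=CCOc1ccc(C(=O)Nc2cccc(NCCCC)n2)cc1`, has not yet been measured. It differs from compound 2 in one place: butylamino in place of hydrogen on an aromatic carbon. Going by the values given here, no step between measured compounds tells how such an amine on the core affects binding. Among the compounds with values here, what the numbers do show is that compound 2, with only a hydrogen at that place, already sits at a weak level, and that compound 3, the one compound carrying an amine substituent on its core, gave no number at all. On that basis the step from compound 2 to compound 4 is expected to weaken inhibition further, by about a 3.1-fold higher number from compound 2 to compound 4 (0.49 log units; beyond the scatter), with a fair chance that the assay again reports only a limit. Compound 4 is therefore estimated at 60000 nM, within a range from 20000 nM to 200000 nM.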

Compound 4, half-maximal inhibitory concentration: 22400 nM
The estimate for compound 4 lay 2.7-fold (0.43 log units) above the measured number; the measured number falls inside the stated range.
By their numbers in this assay, from the lowest: compounds 1, 2 and 4 (each within the scatter of the next). At a limit, above all of these: compound 3.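

In this assay, the place on the aromatic carbon next to the ring nitrogen now has its first readable step: butylamino in place of hydrogen gives a 1.2-fold higher number from compound 2 to compound 4 (0.06 log units; within the scatter). The earlier compounds shown here could not show this, as no two of them differed in one place only, and here a whole chain with an amine nitrogen replaces a bare hydrogen without moving the number beyond the usual scatter, so this one change shows no measurable effect on inhibition, in either direction. Compound 3 is still the only compound reported as a limit rather than a number: the limit of > 100000 nM in this assay, at which 1 of the 4 values shown sits.

Compound 3 differs from compound 4 in more than one place, so the compounds shown cannot tie that limit to any single difference between them. From the compounds shown here alone, whether a different group at this same place, such as a carboxylic acid, a hydroxyl or a much longer alkylamino chain, would move the number beyond the scatter also stays open, and one step with butylamino cannot settle it.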